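Adding a second methoxy to compound 2

A few compounds are considered here, and "the series" means these few. Any claim that something is new, unique, unknown or untested is made for them only; others in the source may bear on it.

Measured in an ADME assay on HEK-293T cells (Homo sapiens) for cytotoxicity, read by MTT assay, with a stated time of 48 h (on this read-out higher numbers stand for lower toxicity in this test and lower numbers for higher toxicity in this test), both values being limits of the assay:
compound 1 `Cn1cc(C2CC(c3ccccc3)=NN2C(=O)c2cccnc2)c2cc(Br)ccc21` gives > 300000 nM (limit)
compound 2 `COc1ccc(C2=NN(C(=O)c3cccnc3)C(c3cn(C)c4ccc(Br)cc34)C2)cc1` gives > 300000 nM (limit)

Among the measured compounds shown here, compound 2 has no exact number, only a limit, and the one further value is a limit too. Together they show the limit of > 300000 nM in this assay, at which 2 of the 2 values shown sit, and nothing finer.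

Compound 3 `COc1ccc(C2=NN(C(=O)c3cccnc3)C(c3cn(C)c4ccc(Br)cc34)C2)cc1OC` keeps everything in compound 2 except that 4-methoxyphenyl becomes 3,4-dimethoxyphenyl: methoxy in place of hydrogen on an aromatic carbon (the new methoxy sits ortho to the existing one).

For the measured compounds named here, the one measured step that bears on this (a step that the two limits leave unreadable from compound 1 to compound 2) is the same kind of swap, yet it offers no size to carry over. No step beyond the usual scatter is therefore expected in this assay for this change, in either direction. The expected step is a number no higher from compound 2 to compound 3 (the limit leaves the size open) (an estimate resting on a limit). Compound 3 is estimated at 300000 nM (expected range 100000 nM to 600000 nM) and will most likely be reported only as a limit again.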

Compound 3, half-maximal cytotoxic concentration: > 300000 nM
Compound 3 ended at the assay's limit; the forecaster's own chance of this, stated with the estimate: 85%; the middle value lies on the limit itself.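

No step can be read between compound 1, compound 2 and compound 3, since each value is only a limit and not a number: the limit of > 300000 nM in this assay, at which 3 of the 3 values shown sit.

The compounds shown leave open how far each lies from that limit in this assay and whether the added methoxy changes the read-out at all.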